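The compounds below may be only part of what the source reports. "The series", "measured", "known", "first", "only" and "open" are said of these compounds alone.

Compound 3 `CC(C(=O)NCc1ccc(C(F)(F)F)nc1N1CCC(=O)CC1)c1ccc(NS(C)(=O)=O)c(F)c1` gives 91 nM in a functional assay on CHO-K1 cells for antagonist activity at transient receptor potential cation channel subfamily V member 1 (Homo sapiens), read by FLIPR (a lower number here means a stronger inhibitor, a higher number a weaker inhibitor), the highest of the three numbers measured here. Compound 1 `CCCCN(C)c1nc(C(F)(F)F)ccc1CNC(=O)C(C)c1ccc(NS(C)(=O)=O)c(F)c1` gives 0.8 nM in this assay, and compound 2 `CC(C(=O)NCc1ccc(C(F)(F)F)nc1N1CCCCC1C)c1ccc(NS(C)(=O)=O)c(F)c1` gives 2.9 nM. Compound 4 `CC(C(=O)NCc1ccc(C(F)(F)F)nc1N1CCCCCCC1)c1ccc(NS(C)(=O)=O)c(F)c1` differs from compound 3 in one place: a group of 8 heavy atoms (7 carbon, 1 nitrogen; one eight-membered non-aromatic ring with 1 hetero atom) in place of a group of 7 heavy atoms (5 carbon, 1 nitrogen, 1 oxygen; one six-membered non-aromatic ring with 1 hetero atom), on an aromatic carbon. Going by the values given here, the steps that bear on this are a 110-fold higher number from compound 1 to compound 3 (2.06 log units; beyond the scatter) and a 31-fold higher number from compound 2 to compound 3 (1.50 log units; beyond the scatter), both large. Those two steps show that the 4-oxopiperidin-1-yl group stands far apart from the other two amine groups on the same carbon. Because compound 2 with its ring amine gives 2.9 nM, the eight-membered ring in compound 4 is expected to bring a large step downward, a 23-fold lower number from compound 3 to compound 4 (1.36 log units; beyond the scatter). Compound 4 is therefore estimated at 4 nM, with a range from 1 nM to 16 nM.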

Compound 4, inhibition constant: 0.7 nM
For compound 4 the middle estimate is 5.7-fold (0.76 log units) above the measured one; the whole stated range lies above it.
By their numbers in this assay, from the lowest: compounds 4 and 1 (each within the scatter of the next); then compound 2; then compound 3.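

In this assay, the 4-oxopiperidin-1-yl group is not simply too large for this position: the larger eight-membered ring gives a 130-fold lower number from compound 3 to compound 4 (2.11 log units; beyond the scatter), and it also improves on the 2-methylpiperidin-1-yl ring, with a 4.1-fold lower number from compound 2 to compound 4 (0.62 log units; beyond the scatter). Against the open-chain butyl(methyl)amino group it shows a 1.1-fold lower number from compound 1 to compound 4 (0.06 log units; within the scatter), so a ring and an open chain both fit here. No measurement shown explains these differences.

Ring size and the carbonyl both change in this one step, leaving their separate shares open. An unsubstituted piperidin-1-yl group would help tell them apart.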